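A few compounds are considered here, and "the series" means these few. Any claim that something is new, unique, unknown or untested is made for them only; others in the source may bear on it.

Measured compounds in a functional assay on KB cells (Homo sapiens) for cytotoxicity, read by MTT assay, with a stated time of 72 h; on this read-out higher numbers stand for weaker inhibition and lower numbers for stronger inhibition:
compound 1, `COc1cc(/C(=C\c2cn(C(C)=O)c3ccc(OCc4ccccc4)cc23)C(=O)O)cc(OC)c1OC`: > 100000 nM
compound 2, `COc1ccccc1/C(=C\c1cn(C(C)=O)c2ccc(OCc3ccccc3)cc12)C(=O)O`: > 100000 nM

Both values are limits of this assay, not numbers. Compound 1 gives only a limit. Compound 2 likewise gives only a limit. The step that the two limits leave unreadable from compound 1 to compound 2 is therefore unreadable in size and direction. Compound 2 stands at the limit of > 100000 nM in this assay, at which 2 of the 2 values shown sit, and no number places it among the series.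

Compound 3, `COc1ccc(OC)c(/C(=C\c2cn(C(C)=O)c3ccc(OCc4ccccc4)cc23)C(=O)O)c1`, remains to be measured in this assay. It differs from compound 2 by methoxy in place of hydrogen on an aromatic carbon. Among the measured compounds shown here, the only measured step, from compound 1 to compound 2, alters the same ring, but both ends sit at the limit, so it gives no size and no direction for the present change. For the measured compounds named here, no other measured step bears on it.

The expectation for compound 3 is that it also reaches only the limit, the step that the limit leaves unreadable from compound 2 to compound 3 being unreadable. Compound 3 is estimated at 150000 nM, with a range from 50000 nM to 400000 nM.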

Compound 3, half-maximal inhibitory concentration: > 100000 nM
Compound 3 ended at the assay's limit; the forecaster's own chance of this, stated with the estimate: 85%; the middle value does not contradict the limit.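

Compound 3, like compound 1 and compound 2, gives only a limit in this assay, so no step among these compounds can be read in size or direction: the limit of > 100000 nM in this assay, at which 3 of the 3 values shown sit.

The compounds shown leave open whether any methoxy pattern on this aromatic ring gives a measurable value.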